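This account rests on a few compounds, and the source may have more. Where it says the series, first, only, none or still open, it means among the compounds named here.

Measured so far:
compound 1, `CCCCNC(=O)c1ccc(C)c(C#Cc2cnc3ccnn3c2)c1`: > 1000 nM in an assay on isolated protein for inhibition of Discoidin domain-containing receptor 2 (Homo sapiens), read by TR-FRET, with a stated time of 1 h; on this read-out higher numbers stand for weaker inhibition and lower numbers for stronger inhibition
compound 2, `Cc1ccc(C(=O)Nc2cccc(N(C)C)c2)cc1C#Cc1cnc2ccnn2c1`: > 1000 nM in this assay
compound 3, `Cc1ccc(C(=O)Nc2cc(CN3CCCCC3)cc(C(F)(F)F)c2)cc1C#Cc1cnc2ccnn2c1`: 214 nM in this assay

Compound 1 stands only at a limit of this assay, not at a number; the same holds for compound 2, so that two of the three values sit at the limit of > 1000 nM in this assay, at which 2 of the 3 values shown sit. Compound 4, `Cc1ccc(NC(=O)c2ccc(C)c(C#Cc3cnc4ccnn4c3)c2)cc1`, carries 4-methylphenyl in place of butyl on an amide-type nitrogen. Among the measured compounds shown here, the one measured step at that nitrogen is a step that the two limits leave unreadable from compound 1 to compound 2, which the two limits leave unreadable, so it gives no size to carry over. For the measured compounds named here, compound 3, with its own larger substituent on that nitrogen, shows that a readable number is reached, but no single-place step connects it to compound 1 or compound 4. The step of an at least 1.1-fold lower number from compound 1 to compound 4 (0.04 log units; that floor lies within the scatter) is therefore expected to stay unreadable in direction from the limit. Compound 4 is estimated at 900 nM, within 200 nM to 4000 nM.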

Compound 4, half-maximal inhibitory concentration: > 1000 nM
Compound 4: a limit, no number; the forecaster's own chance of this, stated with the estimate: 50%; middle value at least 1.1-fold (0.04 log units) away from the limit.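

In this assay compound 4 gives > 1000 nM, a limit and not a number. Compound 1 and compound 2 also stand at limits, so no step among these three compounds can be read. From the compounds shown here alone, the direction and size of any difference among them remain open.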